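The compounds below may be only part of what the source reports. "The series", "measured", "known", "first", "only" and "open" are said of these compounds alone.

In a functional assay on HT-29 cells (Homo sapiens) for inhibition, read by MTT assay, with a stated time of 3 days (on this read-out lower numbers stand for stronger inhibition and higher numbers for weaker inhibition), compound 1 `C=CCOc1cc(/C=C\c2cc(OC)c(OC)c(OC)c2)ccc1OC` gives 29000 nM and compound 2 `COc1ccc(/C=C\c2cc(OC)c(OC)c(OC)c2)cc1OCc1ccccc1` gives 39000 nM with the two standing level inside the scatter. Compound 3 `COc1ccc(COc2cc(/C=C\c3cc(OC)c(OC)c(OC)c3)ccc2OC)cc1` puts methoxy in place of hydrogen on an aromatic carbon, para to a large group, turning benzyloxy to (4-methoxybenzyl)oxy: methoxy in place of hydrogen on an aromatic carbon is the whole difference from compound 2. Among the compounds with values here, the only measured step that bears on this is a 1.3-fold higher number from compound 1 to compound 2 (0.13 log units; within the scatter) and it stays within the scatter. On that single step, no shift beyond the scatter is expected in this assay and the estimated step is a 1.1-fold lower number from compound 2 to compound 3 (0.02 log units; within the scatter) with no direction favoured. For compound 3 the estimate is 37000 nM with 16000 nM to 85000 nM as the expected range.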

Compound 3, half-maximal inhibitory concentration: 47000 nM
Compound 3: the middle estimate sits 1.3-fold (0.10 log units) below what was measured; low and high end bracket the measured number.
By their numbers in this assay, from the lowest: compounds 1, 2 and 3 (each within the scatter of the next).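

In this assay a substituent on the phenyl ring of compound 2 makes no readable difference, with a 1.2-fold higher number from compound 2 to compound 3 (0.08 log units; within the scatter) for methoxy in place of hydrogen. The comparison with the vinyl end of compound 1 agrees, with a 1.6-fold higher number from compound 1 to compound 3 (0.21 log units; within the scatter) on going to 4-methoxyphenyl, so all three groups on this oxygen stand level. Nothing at hand accounts for this. From the compounds shown here alone, whether a group of another kind, such as an amine or a carboxylic acid on that ring, would move the number stays open. So does the effect of a free hydroxyl in place of the whole chain.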